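The compounds below may be only part of what the source reports. "The series", "measured", "known", "first", "only" and "open" are said of these compounds alone.

Compound 1 (`O=C1C=C(NCc2ccccc2)C(=O)c2c1nc1n2[C@H]2OC[C@@H](O)[C@H]2OC1`), with a benzyl group on the amine nitrogen, gives > 8000 nM in a functional assay on HeLa cells (Homo sapiens) for inhibition, read by sulforhodamine B assay (a higher number here means a weaker inhibitor, a lower number a stronger inhibitor), as a limit of the assay and not a number. Compound 2 (`COc1ccccc1NC1=CC(=O)c2nc3n(c2C1=O)[C@H]1OC[C@@H](O)[C@H]1OC3`), with 2-methoxyphenyl in that place, gives 2950 nM in this assay on the same core. For the measured compounds named here, compound 3 (`COc1ccc(NC2=CC(=O)c3nc4n(c3C2=O)[C@H]2OC[C@@H](O)[C@H]2OC4)cc1`), with 4-methoxyphenyl there, gives 4780 nM and so stands with compound 2, the only other compound with a true number, within the scatter.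

Compound 4 (`O=C1C=C(Nc2ccccc2)C(=O)c2c1nc1n2[C@H]2OC[C@@H](O)[C@H]2OC1`) carries phenyl on that nitrogen. Its difference from compound 3 is hydrogen in place of methoxy on an aromatic carbon and amounts to hydrogen in place of methoxy on an aromatic carbon, para to a large group.

Going by the values given here, no measured step removes the methoxy outright, so the evidence is indirect. Moving the methoxy gave a 1.6-fold higher number from compound 2 to compound 3 (0.21 log units; within the scatter) and left the number essentially unchanged. Replacing benzyl gave an at least 2.7-fold lower number from compound 1 to compound 2 (0.43 log units; beyond the scatter) and an at least 1.6-fold lower number from compound 1 to compound 3 (0.22 log units; that floor lies within the scatter) but both of those start from a limit, and neither takes the methoxy away.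

A step beyond the scatter is therefore not expected, in either direction, and the estimated size is a 1.1-fold lower number from compound 3 to compound 4 (0.03 log units; within the scatter) in this assay for this change. Compound 4 is expected at 4500 nM with an estimated range from 2200 nM to 9000 nM for the measurement. As with compound 1, the result could also turn out to be only a limit.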

Compound 4, half-maximal inhibitory concentration: 5620 nM
Compound 4: middle estimate off by 1.2-fold (0.10 log units), on the low side; the measured number falls inside the stated range.
By their numbers in this assay, from the lowest: compounds 2, 3 and 4 (each within the scatter of the next). At a limit, above all of these: compound 1.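

In this assay, the methoxy group can now be judged by its removal rather than by moving it. Hydrogen in place of methoxy on an aromatic carbon, para to a large group, gives a 1.2-fold higher number from compound 3 to compound 4 (0.07 log units; within the scatter), and the same kind of exchange starting from the 2-methoxyphenyl group gives a 1.9-fold higher number from compound 2 to compound 4 (0.28 log units; within the scatter), so both steps show that the methoxy group makes no measurable difference at either place in this assay. Phenyl in place of benzyl on the amine nitrogen gives an at least 1.4-fold lower number from compound 1 to compound 4 (0.15 log units; that floor lies within the scatter), so this step offers only a floor, and it cannot show whether the unsubstituted phenyl group differs from benzyl beyond the scatter, since compound 1 remains a limit and not a number: the limit of > 8000 nM in this assay, at which 1 of the 4 values shown sits.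

Still open, going by these compounds, is whether a group of a different kind on the phenyl ring, such as a carboxylic acid, an amine or a chlorine atom, would move the number beyond the scatter in this assay. The compounds shown also leave open how a longer chain between the amine nitrogen and the phenyl ring, such as 2-phenylethyl, would compare.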